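Swapping bromo for methoxy on a cytotoxicity read-out

This account rests on a few compounds, and the source may have more. Where it says the series, first, only, none or still open, it means among the compounds named here.

Compound 1 `Cc1cccc(S(=O)(=O)c2cccc(N)c2C#N)c1` and compound 2 `Cc1cc(Br)cc(S(=O)(=O)c2cccc(N)c2C#N)c1` share a core and differ in one place. In a functional assay on MT4 cells (Homo sapiens) for cytotoxicity (on this read-out lower numbers stand for stronger inhibition and higher numbers for weaker inhibition), compound 1 gives 179000 nM. In this assay compound 2 gives 133000 nM. For the measured compounds named here, the single measured step, a 1.3-fold lower number from compound 1 to compound 2 (0.13 log units; within the scatter), comes from bromo in place of hydrogen on an aromatic carbon and is within the scatter, so the two values cannot be told apart with confidence. Compound 2 therefore stands beside compound 1 with no separation that the numbers support.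

Compound 3 `COc1cc(C)cc(S(=O)(=O)c2cccc(N)c2C#N)c1` has not yet been measured. It differs from compound 2 as follows: methoxy in place of bromo on an aromatic carbon. Going by the values given here, no measured step describes methoxy in place of bromo, so nothing directly bears on it; the one step that exists, a change at the same aromatic carbon, stayed within the scatter. On that basis no step beyond the scatter is expected in this assay, in either direction. Compound 3 is estimated at 140000 nM, with a range of 70000 nM to 280000 nM. The step expected from this estimate is a 1.1-fold higher number from compound 2 to compound 3 (0.02 log units; within the scatter).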

Compound 3, half-maximal inhibitory concentration: 94000 nM
Estimate against measurement, compound 3: 1.5-fold (0.17 log units) above; the range from low to high includes it.
By their numbers in this assay, from the lowest: compounds 3, 2 and 1 (each within the scatter of the next).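

Replacing bromo with methoxy on this aromatic carbon gives a 1.4-fold lower number from compound 2 to compound 3 (0.15 log units; within the scatter) in this assay and replacing the hydrogen of compound 1 with methoxy gives a 1.9-fold lower number from compound 1 to compound 3 (0.28 log units; within the scatter) so neither step separates the compounds. The earlier compounds shown here showed this only for hydrogen and bromo, whereas the position has now taken a group with an oxygen atom and a hydrogen-bond acceptor by count, still without a step beyond the scatter. Why the read-out stays so close across hydrogen, bromo and methoxy cannot be said, as no separate measurement bears on the cause.

Still open, from the compounds shown here alone, is whether a group of another kind at this same aromatic carbon, such as an amine, a carboxylic acid or a longer chain like butoxy, would give a step beyond the scatter. Since the compounds shown differ only at this one carbon, they also leave open how this read-out would respond to changing the methyl group, the nitrile or the amine already on the shared core.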